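The compounds below may be only part of what the source reports. "The series", "measured", "known", "first", "only" and "open" are said of these compounds alone.

Measured compounds:
compound 1, `CN(C)CCn1cnnc1-c1cc(Oc2ccc(NC(=O)N/N=C/c3ccc(O)c(Br)c3)cc2F)ccn1`, 430 nM
compound 2, `CN(C)CCn1cnnc1-c1cc(Oc2ccc(NC(=O)N/N=C/c3ccccc3O[N+](=O)[O-])cc2F)ccn1`, 1270 nM
compound 3, `CN(C)CCn1cnnc1-c1cc(Oc2ccc(NC(=O)N/N=C/c3ccc(F)cc3)cc2F)ccn1`, 1980 nM

In a functional assay on NCI-H460 cells (Homo sapiens) for cytotoxicity, read by MTT assay, with a stated time of 72 h (a higher number here means a weaker inhibitor, a lower number a stronger inhibitor), compound 3 gives the highest of the three numbers. Its nearest neighbour is compound 2, separated by a 1.6-fold higher number from compound 2 to compound 3 (0.19 log units; within the scatter), while compound 1 lies furthest away, separated by a 4.6-fold higher number from compound 1 to compound 3 (0.66 log units; beyond the scatter). Only the aryl group on the carbon with a double bond to nitrogen varies across the three.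

Compound 4, `CN(C)CCn1cnnc1-c1cc(Oc2ccc(NC(=O)N/N=C/c3ccc(O)cc3O)cc2F)ccn1`, continues this variation: 2,4-dihydroxyphenyl in place of 4-fluorophenyl on a carbon with a double bond to nitrogen. The step bearing most directly on it is a 4.6-fold higher number from compound 1 to compound 3 (0.66 log units; beyond the scatter), where a 3-bromo-4-hydroxyphenyl at the same place gave the lowest number in the set; the step of a 3.0-fold higher number from compound 1 to compound 2 (0.47 log units; beyond the scatter) points the same way. For the measured compounds named here, a 2,4-dihydroxyphenyl shares a hydroxyl-bearing aryl with compound 1 and is therefore expected to move the number back down by a step of roughly a 3.6-fold lower number from compound 3 to compound 4 (0.56 log units; beyond the scatter), beyond the scatter, though no compound with two hydroxyls has been measured here.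

Compound 4 is expected to give about 550 nM in this assay, within a range of 200 nM to 1600 nM.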

Compound 4, half-maximal inhibitory concentration: 11300 nM
Beside the measured number, compound 4's estimate is 21-fold (1.31 log units) below it; the measured number lies above the stated range.
By their numbers in this assay, from the lowest: compound 1; then compounds 2 and 3 (each within the scatter of the next); then compound 4.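

In this assay, for the compounds shown here, a hydroxyl on the aryl group at the carbon with a double bond to nitrogen does not by itself keep the number low: compound 1 also bears one, yet 2,4-dihydroxyphenyl gives a 26-fold higher number from compound 1 to compound 4 (1.42 log units; beyond the scatter) and is the only large step in the set. Compound 4 also ends above both aryl groups without a hydroxyl, with a 5.7-fold higher number from compound 3 to compound 4 (0.76 log units; beyond the scatter) and an 8.9-fold higher number from compound 2 to compound 4 (0.95 log units; beyond the scatter) as the steps, so this position spans a wider range than the first three compounds showed. Nothing available accounts for these steps.

Still open, on these data alone, is whether one hydroxyl or the pair goes with the high number, which 2-hydroxyphenyl, 4-hydroxyphenyl and 2,4-dimethoxyphenyl at this place would help separate. A 3-bromophenyl would likewise test how much the bromine of compound 1 goes with its low number.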